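Removing a methyl from the isobutylsulfanyl chain of compound 1

A few compounds are considered here, and "the series" means these few. Any claim that something is new, unique, unknown or untested is made for them only; others in the source may bear on it.

The measured compounds in a functional assay on HeLa cells (Homo sapiens) for antiproliferative activity, read by CCK-8 assay, with a stated time of 48 h; on this read-out lower numbers stand for stronger inhibition and higher numbers for weaker inhibition:
- compound 1, `CC(C)CSc1n[nH]c(-n2[se]c3ccccc3c2=O)n1`, gives 34900 nM
- compound 2, `O=c1c2ccccc2[se]n1-c1nc(SCc2ccc(Cl)cc2)n[nH]1`, gives 40900 nM
- compound 3, `O=c1c2ccccc2[se]n1-c1nc(SCc2ccc(F)cc2)n[nH]1`, gives only a limit of > 50000 nM

Among the two numbers shown, compound 1 has the lowest, with compound 2 nearest at a 1.2-fold higher number from compound 1 to compound 2 (0.07 log units; within the scatter). Compound 3 sits at a limit of the assay rather than at a number, (the limit of > 50000 nM in this assay, at which 1 of the 3 values shown sits).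

Compound 4, `CCCSc1n[nH]c(-n2[se]c3ccccc3c2=O)n1`, has not yet been measured in this assay. It differs from compound 1 by hydrogen in place of methyl on a saturated chain carbon bound to two saturated chain carbons.

Two measured steps start from compound 1 at the same chain: a 1.2-fold higher number from compound 1 to compound 2 (0.07 log units; within the scatter) and an at least 1.4-fold higher number from compound 1 to compound 3 (0.15 log units; that floor lies within the scatter). Both replace the isopropyl with an aryl group, so neither is the same change as the loss of a methyl, and both stay within the scatter. Within the data shown here, no measured step removes a methyl from this chain. The expectation for compound 4 is therefore a step from compound 1 of about a 1.1-fold higher number from compound 1 to compound 4 (0.06 log units; within the scatter), not beyond the scatter in either direction. Compound 4 is estimated at 40000 nM, within 20000 nM to 80000 nM.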

Compound 4, half-maximal inhibitory concentration: 30400 nM
Beside the measured number, compound 4's estimate is 1.3-fold (0.12 log units) above it; low and high end bracket the measured number.
By their numbers in this assay, from the lowest: compounds 4, 1 and 2 (each within the scatter of the next). At a limit, above all of these: compound 3.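

In this assay, among these compounds, the change from isobutylsulfanyl to propylsulfanyl is the first step that alters only the alkyl chain, and it gives a 1.1-fold lower number from compound 1 to compound 4 (0.06 log units; within the scatter), so removing this methyl leaves the read-out within the scatter. The steps from the two aryl compounds read the same way, with a 1.3-fold lower number from compound 2 to compound 4 (0.13 log units; within the scatter) and an at least 1.6-fold lower number from compound 3 to compound 4 (0.21 log units; that floor lies within the scatter), so on the saturated chain carbon bound to a sulfur, ethyl is not told apart from 4-chlorophenyl, and the floor of the step from 4-fluorophenyl does not separate those two groups either. Compound 3 stands at a limit and not at a number: the limit of > 50000 nM in this assay, at which 1 of the 4 values shown sits.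

The compounds shown leave open whether any group at this place moves the number beyond the scatter. A longer chain, an amine or a carboxylic acid at the end of the chain does not stand among them.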